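Chloro in Place of Hydrogen on the Shared Core

The compounds below may be only part of what the source reports. "The series", "measured", "known", "first", "only" and "open" are said of these compounds alone.

For the measured compounds named here, compound 1 `c1cc(-c2ccn[nH]2)c2c(c1)C(c1ncc[nH]1)CC2` is the only compound here with a number: in a functional assay on CHO cells for agonist activity at Alpha-1D adrenergic receptor (Homo sapiens), read by FLIPR and calcium flux (a lower number here means that less compound is needed, a higher number that more compound is needed for the effect), compound 1 gives 336 nM. Compound 2 `Cc1oncc1-c1cccc2c1CCC2c1ncc[nH]1` carries a 5-methyl-1,2-oxazol-4-yl in place of the 1H-pyrazol-5-yl; its value in this assay is a limit, > 10000 nM. The step of an at least 29-fold higher number from compound 1 to compound 2 (1.47 log units; beyond the scatter) is large and shows that swapping the five-membered heteroaromatic ring costs much activity, as the value sits at the limit of > 10000 nM in this assay, at which 1 of the 2 values shown sits. Compound 3 `Clc1ccc2c(c1-c1ccn[nH]1)CCC2c1ncc[nH]1` keeps that ring and instead has chloro in place of hydrogen on an aromatic carbon, ortho to the 1H-pyrazol-5-yl group. Going by the values given here, no measured step here involves adding a chlorine, so the measured step does not bear directly on this change. Compound 3 is therefore expected to stay near compound 1, with the step of a 1.2-fold higher number from compound 1 to compound 3 (0.08 log units; within the scatter) not clearly beyond the scatter. Compound 3 is estimated at 400 nM, within 100 nM to 2000 nM.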

Compound 3, half-maximal effective concentration: > 10000 nM
Compound 3 was reported as a limit; the forecaster's own chance of this, stated with the estimate: 10%; middle value at least 25-fold (1.39 log units) away from the limit.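

In this assay, putting a chloro on an aromatic carbon, ortho to the 1H-pyrazol-5-yl group, gives an at least 29-fold higher number from compound 1 to compound 3 (1.47 log units; beyond the scatter). Earlier, only exchanging the 1H-pyrazol-5-yl group itself had been seen to cost activity; this result shows that a change of a single atom at this position of the shared core can also cost much activity, even with the 1H-pyrazol-5-yl group kept in place. Compound 3 and compound 2 are both reported only as a limit, so they cannot be ordered against each other: the limit of > 10000 nM in this assay, at which 2 of the 3 values shown sit.

The compounds shown leave open whether this loss is specific to chloro, or whether a fluoro, a methyl or an amine at the same position would cost as much. As far as these compounds go, with only a limit for compound 3, the full size of the step also stays open.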